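This account rests on a few compounds, and the source may have more. Where it says the series, first, only, none or still open, it means among the compounds named here.

Working notes on the series.

Compound 1 `COc1ccc2[nH]c(-c3ccccc3)c(C3=C(Br)C(=O)NC3=O)c2c1` and compound 2 `CCOc1ccc2[nH]c(-c3ccccc3)c(C3=C(Br)C(=O)NC3=O)c2c1` share a core; in a physicochemical assay for lipophilicity (a higher number here means a more lipophilic compound, a lower number a more polar compound), compound 1 gives 2.48 and compound 2 gives 2.77. The change between them, (methyl in place of hydrogen on a saturated chain carbon bound to an oxygen on an aromatic ring), moves the number a number 0.29 log units higher from compound 1 to compound 2 (within the scatter).

Compound 3 `CCCOc1ccc2[nH]c(-c3ccc(OC)cc3)c(C3=C(Br)C(=O)NC3=O)c2c1` carries a different core; the difference between the two cores is not broken down here. In this assay compound 3 gives 3.12, the highest of the three values, with compound 2 nearest and compound 1 furthest.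

Compound 4 `CCCCOc1ccc2[nH]c(-c3ccc(OC)cc3)c(C3=C(Br)C(=O)NC3=O)c2c1` is not yet measured. Against compound 3 the change is methyl in place of hydrogen on a saturated chain carbon, three bonds along the chain from an oxygen on an aromatic ring. It is the same kind of change as from compound 1 to compound 2, but not the same: there the place was on a saturated chain carbon bound to an oxygen on an aromatic ring, here on a saturated chain carbon three bonds along the chain from an oxygen on an aromatic ring.

The step is expected to be a number 0.38 log units higher from compound 3 to compound 4 (beyond the scatter), resting on the measured step of a number 0.29 log units higher from compound 1 to compound 2 (within the scatter). Compound 4 is estimated at 3.5, between 3.2 and 3.85.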

Compound 4, partition coefficient: 3.43
The estimate for compound 4 lay 0.07 log units above the measured number, and the stated range covers the measured number.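

In this assay the number is a number 0.31 log units higher from compound 3 to compound 4 (beyond the scatter) and points the same way as the earlier step, a number 0.29 log units higher from compound 1 to compound 2 (within the scatter), on the core of compound 1. The direction of the change therefore held across these two cores, but this is one step on each core, and the place also differs: on a saturated chain carbon bound to an oxygen on an aromatic ring in the earlier step, and three bonds along the chain from that oxygen in the new one, which leaves any effect of the core unseparated from any effect of the place and supports no general rule. Nothing given here bears on what lies behind either step.

The compounds shown leave open whether the same step would appear at each place on both cores, and whether it would continue with a longer chain such as pentyl or hexyl. They also leave open how an amine or a carboxylic acid on that chain would read in this assay on either core.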